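Alkyne aryl variation on the shared core

The source may hold more compounds than are shown below. What is called first, only, known or untested is meant among the compounds shown, and "the series" means these compounds.

Measured so far in a functional assay on NCI-H460 cells (Homo sapiens) for inhibition, read by sulforhodamine B assay, with a stated time of 48 h; a higher number here means a weaker inhibitor of growth, a lower number a stronger inhibitor of growth:
compound 1, `COC(=O)c1sc2cc(C#Cc3ccc(OC)cc3)cnc2c1N`: 320 nM
compound 2, `COC(=O)c1sc2cc(C#Cc3ccccc3F)cnc2c1N`: a limit of the assay, > 150000 nM
compound 3, `COC(=O)c1sc2cc(C#Cc3cccc(OC)c3)cnc2c1N`: 49000 nM

Compound 3 gives the highest of the two numbers; the nearest is compound 1, with a 150-fold higher number from compound 1 to compound 3 (2.19 log units; beyond the scatter). For compound 2 the assay reports only a limit, (the limit of > 150000 nM in this assay, at which 1 of the 3 values shown sits).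

Compound 4, `COC(=O)c1sc2cc(C#Cc3ccccc3)cnc2c1N`, differs from compound 3 by hydrogen in place of methoxy on an aromatic carbon, that is 3-methoxyphenyl to phenyl. For the measured compounds named here, no measured step removes a methoxy group; the two steps that do exist, a 150-fold higher number from compound 1 to compound 3 (2.19 log units; beyond the scatter) and an at least 460-fold higher number from compound 1 to compound 2 (2.67 log units; beyond the scatter), both move away from the 4-methoxyphenyl of compound 1 and are large, and an at least 3.0-fold lower number from compound 2 to compound 3 (0.48 log units; beyond the scatter) is at least modest. The direction of the present change is therefore not fixed by the data. Compound 3 already stands high, and a change of the aryl ring away from compound 1 has so far only raised the number, so compound 4 is expected to remain in the weak range with a wide spread: the estimated step is a 1.6-fold higher number from compound 3 to compound 4 (0.21 log units; within the scatter). The estimate for compound 4 in this assay is 80000 nM, between 15000 nM and 400000 nM.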

Compound 4, concentration for 50% growth inhibition: > 150000 nM
Compound 4 ended at the assay's limit; the forecaster's own chance of this, stated with the estimate: 35%; at least 1.8-fold (0.27 log units) between middle value and limit.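

In this assay the methoxy group of compound 3 proves to count even on a weak compound, with an at least 3.0-fold higher number from compound 3 to compound 4 (0.48 log units; beyond the scatter) on its replacement by hydrogen. The phenyl ring also falls far short of the 4-methoxyphenyl ring, with an at least 460-fold higher number from compound 1 to compound 4 (2.67 log units; beyond the scatter) and thus a step of the same reach as the largest seen so far, so among the compounds shown, only the 4-methoxyphenyl ring gives a value far from the limit. Compound 2 and compound 4 both stand at a limit of the assay, so the step between them cannot be read: the limit of > 150000 nM in this assay, at which 2 of the 4 values shown sit.

Going by these compounds, whether another group at the place of the 4-methoxy group, such as ethoxy, hydroxyl or an amine, would hold the growth inhibition of compound 1 stays open. On these data alone, the full size of the loss on removing methoxy also stays open, since only a bound on it can be read.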